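This account rests on a few compounds, and the source may have more. Where it says the series, first, only, none or still open, it means among the compounds named here.

Working notes on the series. Three compounds share one core and differ only in the aryl group on an oxygen on a saturated carbon. Compound 1 `O=C(O)c1cncc(-c2ccc(N3CCC(Oc4ccccc4Cl)CC3)nn2)c1` gives 166 nM in an assay on isolated protein for inhibition of acyl-CoA desaturase 1 (Rattus norvegicus); on this read-out higher numbers stand for weaker inhibition and lower numbers for stronger inhibition. Compound 2 `O=C(O)c1cncc(-c2ccc(N3CCC(Oc4cc(F)c(F)cc4Br)CC3)nn2)c1` gives 15 nM, and compound 3 `O=C(O)c1cncc(-c2ccc(N3CCC(Oc4cc(F)ccc4Br)CC3)nn2)c1` gives 15 nM. On these numbers compound 3 stands level with compound 2 and, together with it, at the lowest of the three values; compound 1 lies furthest away, an 11-fold lower number from compound 1 to compound 3 (1.04 log units; beyond the scatter).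

Compound 4 `O=C(O)c1cncc(-c2ccc(N3CCC(Oc4c(F)cc(F)cc4Br)CC3)nn2)c1` is the next step from compound 3: 2-bromo-4,6-difluorophenyl in place of 2-bromo-5-fluorophenyl on an oxygen on a saturated carbon. The bromine stays; only the fluorine pattern on the ring changes. Two of the measured steps bear on this. The large ones, an 11-fold lower number from compound 1 to compound 2 (1.04 log units; beyond the scatter) and an 11-fold lower number from compound 1 to compound 3 (1.04 log units; beyond the scatter), each swap the halogen and add fluorine together, so they do not isolate the fluorine contribution. The step that does, no change at the digits printed from compound 2 to compound 3 (within the scatter), shows that adding or removing a fluorine on this ring leaves the number where it was. For compound 4 a change of about the same size is therefore expected, that is none beyond the scatter, a 1.1-fold higher number from compound 3 to compound 4 (0.03 log units; within the scatter). Compound 4 is estimated at 16 nM in this assay, with a range from 6 nM to 45 nM.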

Compound 4, half-maximal inhibitory concentration: > 20000 nM
Compound 4: only a limit was reported; the forecaster's own chance of this, stated with the estimate: 2%; at least 1200-fold (3.09 log units) between middle value and limit.
By their numbers in this assay, from the lowest: compounds 2 and 3 (each within the scatter of the next); then compound 1. At a limit, above all of these: compound 4.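

Compound 4 is reported in this assay only as a limit, not as a number: the limit of > 20000 nM in this assay, at which 1 of the 4 values shown sits. Within the data shown here, with the bromine kept and only the fluorine pattern altered, the aryl group on an oxygen on a saturated carbon is far less forgiving than compounds 2 and 3 suggested: there is an at least 1300-fold higher number from compound 3 to compound 4 (3.12 log units; beyond the scatter), and likewise an at least 1300-fold higher number from compound 2 to compound 4 (3.12 log units; beyond the scatter), whereas the single fluorine change between the two earlier compounds stayed within the scatter. The 2-bromo-4,6-difluorophenyl group also fares worse than the 2-chlorophenyl group, with an at least 120-fold higher number from compound 1 to compound 4 (2.08 log units; beyond the scatter), so a bromine on the ring does not by itself secure a low number at this position.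

The compounds shown leave open which of the two fluorines of the 2-bromo-4,6-difluorophenyl group accounts for the loss, or whether it takes both together. They also leave open whether a chlorine in place of the bromine, or a methyl or methoxy group in place of either fluorine, would keep the same limit or return the number to the range of compounds 2 and 3.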